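Aryl ether variation in the hydroxamate series

The compounds below may be only part of what the source reports. "The series", "measured", "known", "first", "only" and "open" are said of these compounds alone.

Among the compounds with values here, compound 1 `Cc1cc(F)cc(C)c1Oc1ccc(C(C)(C)O)cc1-c1cn(C)c(=O)c2[nH]c(C(=O)NCc3ccc(C(=O)NO)cc3)cc12` stands highest of the three numbers so far in an assay on isolated protein for inhibition of protein deacetylase HDAC6 (Homo sapiens), read by fluorescence (a higher number here means a weaker inhibitor, a lower number a stronger inhibitor), with 39.3 nM. Within the data shown here, compound 3 `Cc1cc(F)cc(C)c1Oc1ccc(C(C)(C)O)cc1-c1cn(C)c(=O)c2[nH]c(C(=O)NCCCCCCC(=O)NO)cc12` gives 17.2 nM, and a 2.3-fold lower number from compound 1 to compound 3 (0.36 log units; beyond the scatter) is the only single-point step measured. Compound 2 `Cn1cc(-c2ccccc2Oc2ccccc2)c2cc(C(=O)NCCCCCC(=O)NO)[nH]c2c1=O` gives 3.4 nM, but differs from compound 1 in more than one place. Compound 4 `Cn1cc(-c2cc(C(C)(C)O)ccc2Oc2ccc(F)cc2F)c2cc(C(=O)NCc3ccc(C(=O)NO)cc3)[nH]c2c1=O` carries 2,4-difluorophenyl in place of 4-fluoro-2,6-dimethylphenyl on an oxygen on an aromatic ring. Among the measured compounds shown here, no measured step touches this part of the molecule: the step from compound 1 to compound 3 alters the linker to the hydroxycarbamoyl group instead, and compound 2 alters both the ether and the linker at once. For compound 4 no step beyond the scatter is expected, a 1.0-fold higher number from compound 1 to compound 4 (0.01 log units; within the scatter). Compound 4 is therefore estimated at 40 nM, within 15 nM to 110 nM.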

Compound 4, half-maximal inhibitory concentration: 15.6 nM
Compound 4: the middle estimate sits 2.6-fold (0.41 log units) above what was measured, and the stated range covers the measured number.
By their numbers in this assay, from the lowest: compound 2; then compounds 4 and 3 (each within the scatter of the next); then compound 1.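

In this assay, within the data shown here, the aryl ether position responds to substitution: 2,4-difluorophenyl in place of 4-fluoro-2,6-dimethylphenyl gives a 2.5-fold lower number from compound 1 to compound 4 (0.40 log units; beyond the scatter), the only single-place reading at this position, as the earlier step changed the linker. No supporting measurement bears on this step.

The compounds shown do not separate the loss of the methyl groups from the gain of the second fluorine. Also open, going by these compounds, are whether the step carries over to the 5-(hydroxycarbamoyl)pentyl chain of compound 3, and how a phenyl ring bearing an amine or a carboxylic acid would read at this oxygen.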